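The source may hold more compounds than are shown below. What is called first, only, known or untested is meant among the compounds shown, and "the series" means these compounds.

Measured compounds in a functional assay on SGC-7901 cells (Homo sapiens) for inhibition, read by MTT assay, with a stated time of 48 h; on this read-out lower numbers stand for stronger inhibition and higher numbers for weaker inhibition:
Compound 1 `Cc1nnsc1CO/N=C/c1c(C)nn(C)c1Oc1ccccc1Cl` gives > 50000 nM, which is a limit of the assay.
Compound 2 `Cc1nnsc1CO/N=C/c1c(C)nn(C)c1Oc1cccc(F)c1` gives > 50000 nM, which is likewise a limit of the assay.

Compound 2 therefore stands at the limit of this assay and carries no number of its own. Among the compounds with values here, the single measured step, a step that the two limits leave unreadable from compound 1 to compound 2, cannot be read because the limit of > 50000 nM in this assay, at which 2 of the 2 values shown sit, holds at both of its ends. Compound 3 `Cc1nnsc1CO/N=C/c1c(C)nn(C)c1Oc1cccc(C(F)(F)F)c1` differs from compound 2 by trifluoromethyl in place of fluoro on an aromatic carbon. Both shown values are limits, so no measured step bears on this change with a readable size. No step beyond the scatter in this assay can be expected in either direction, and the most likely outcome is that compound 3 also returns a limit. The step is expected as a step that the limit leaves unreadable from compound 2 to compound 3. Compound 3 is accordingly estimated at 60000 nM, within a range from 20000 nM to 200000 nM.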

Compound 3, half-maximal inhibitory concentration: 12400 nM
Estimate against measurement, compound 3: 4.8-fold (0.68 log units) above, and the stated range ends above it.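

Trifluoromethyl in place of fluoro on an aromatic carbon, meta to a large group, gives in this assay an at least 4.0-fold lower number from compound 2 to compound 3 (0.60 log units; beyond the scatter), the only step among these compounds with a readable size; the step between compound 1 and compound 2 cannot be read. This shows that a change at this position can bring a compound of this set off the limit and give it a number of its own. The true size of the step stays open at its upper end, and the printed size is only a floor: the limit of > 50000 nM in this assay, at which 2 of the 3 values shown sit.

Whether the drop in the number belongs to trifluoromethyl alone remains open, since no other group, such as a nitrile, a methoxy or an amine, stands at this place among the compounds shown. As far as these compounds go, it is also open whether the same group would act alike elsewhere on that ring.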